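This account rests on a few compounds, and the source may have more. Where it says the series, first, only, none or still open, it means among the compounds named here.

Going by the values given here, compound 2 `CC=CCn1c(N[C@@H]2C[C@H](c3ccccc3)CN(C)C2)nc2cc[nH]c2c1=O` gives 3040 nM in an assay on isolated protein for binding affinity to histone acetyltransferase KAT2B (Homo sapiens), read by isothermal titration calorimetry (on this read-out lower numbers stand for tighter binding and higher numbers for weaker binding), the higher of the two numbers so far; compound 1 `C=CCn1c(N[C@@H]2C[C@H](c3ccccc3)CN(C)C2)nc2cc[nH]c2c1=O` gives 676 nM. Among the compounds with values here, the one step on record, a 4.5-fold higher number from compound 1 to compound 2 (0.65 log units; beyond the scatter), came with the methyl added to the double-bonded chain carbon. Compound 3 `CCn1c(N[C@@H]2C[C@H](c3ccccc3)CN(C)C2)nc2cc[nH]c2c1=O` differs from compound 2 by methyl in place of prop-1-en-1-yl on a saturated chain carbon bound to an aromatic nitrogen, which takes away both that methyl and the double bond. Within the data shown here, only the step from compound 1 to compound 2 bears on it, and it points downward, so compound 3 is expected to show a 3.8-fold lower number from compound 2 to compound 3 (0.58 log units; beyond the scatter) in this assay. The estimate for compound 3 is 800 nM, within 250 nM to 2500 nM.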

Compound 3, dissociation constant: 621 nM
Estimate against measurement, compound 3: 1.3-fold (0.11 log units) above; the measured number falls inside the stated range.
By their numbers in this assay, from the lowest: compounds 3 and 1 (each within the scatter of the next); then compound 2.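

On the saturated chain carbon bound to an aromatic nitrogen, methyl in place of prop-1-en-1-yl gives a 4.9-fold lower number from compound 2 to compound 3 (0.69 log units; beyond the scatter) and methyl in place of vinyl gives a 1.1-fold lower number from compound 1 to compound 3 (0.04 log units; within the scatter). The double bond is therefore not required to hold the number seen for compound 1, and among these three compounds only but-2-en-1-yl stands apart. No measurement on hand accounts for this difference.

Still open, from the compounds shown here alone, is whether propyl, a saturated chain of the same length as but-2-en-1-yl, stands with ethyl or with but-2-en-1-yl. Also open, going by these compounds, is how a longer chain or a benzyl group would read here.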